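Moving the hydroxyl around the pyridine-flanking phenyl ring

This account rests on a few compounds, and the source may have more. Where it says the series, first, only, none or still open, it means among the compounds named here.

Compound 1 `Oc1ccc(-c2cc(-c3cccc(F)c3)cc(-c3cccc(O)c3)n2)cc1` was tested in a functional assay on T47D cells (Homo sapiens) for inhibition (a lower number here means a stronger inhibitor, a higher number a weaker inhibitor), and gave 3510 nM. Compound 2 `Oc1ccc(-c2cc(-c3ccc(C(F)(F)F)cc3)cc(-c3ccccc3O)n2)cc1` carries a 2-hydroxyphenyl and a 4-(trifluoromethyl)phenyl on the shared core. In this assay compound 2 reached only the limit of the method, reported as > 50000 nM. It thus stands at the weak end of the two values shown, and the evidence on this point is simply (the limit of > 50000 nM in this assay, at which 1 of the 2 values shown sits). Compound 1 and compound 2 differ in more than one place, so their two values show only that one is a measured number and the other a limit.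

Compound 3 `Oc1ccc(-c2cc(-c3ccc(C(F)(F)F)cc3)cc(-c3cccc(O)c3)n2)cc1` keeps the 4-(trifluoromethyl)phenyl of compound 2 and changes one thing: 3-hydroxyphenyl in place of 2-hydroxyphenyl on an aromatic carbon. From the compounds shown here alone, compound 1 also carries a 3-hydroxyphenyl and gives a measured number, so compound 3 is expected to sit clearly on the stronger side of the limit seen for compound 2, though where the trifluoromethyl-bearing partner leaves it remains open. The author estimates for compound 3 a step of an at least 5.0-fold lower number from compound 2 to compound 3 (0.69 log units; beyond the scatter), giving 10000 nM with a range from 2500 nM to 50000 nM in this assay.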

Compound 3, half-maximal inhibitory concentration: 2870 nM
The estimate for compound 3 lay 3.5-fold (0.54 log units) above the measured number, within the range that was stated.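

With the 4-(trifluoromethyl)phenyl held fixed, 3-hydroxyphenyl in place of 2-hydroxyphenyl on the aromatic carbon next to the ring nitrogen gives an at least 17-fold lower number from compound 2 to compound 3 (1.24 log units; beyond the scatter) in this assay, so this one change separates a measured inhibitor from a compound at the assay's limit. Compound 2 stands at a limit and not at a number, which leaves the true size of this step open on one side: the limit of > 50000 nM in this assay, at which 1 of the 3 values shown sits. With the 3-hydroxyphenyl kept, 4-(trifluoromethyl)phenyl in place of 3-fluorophenyl gives a 1.2-fold lower number from compound 1 to compound 3 (0.09 log units; within the scatter), so in this pair the read-out does not tell the two groups apart.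

The compounds shown cover only two placements of the hydroxyl on this ring, so it remains open whether a 4-hydroxyphenyl at this position, or a methoxy group or an amine in place of the hydroxyl, would stay at the level of compound 3. From the compounds shown here alone, it also remains open whether the 2-hydroxyphenyl would fall to the same limit with the 3-fluorophenyl of compound 1 as its partner.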